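Notes on compound 4 and its measured neighbours

The source may report more compounds than this note shows. Statements on the series, on what has been measured and on what is new or still open speak of the compounds shown alone.

Compound 1 `COc1ccc(-c2cc(/C=C/C(=O)c3ccc(N)cc3)[nH]n2)cc1` and compound 2 `COc1ccc(-c2cc(/C=C/C(=O)c3ccc(N)cc3)[nH]n2)cc1OC` share one core. In a functional assay on MDA-MB-435 cells (Homo sapiens) for inhibition, read by sulforhodamine B assay, with a stated time of 48 h (a higher number here means a weaker inhibitor of growth, a lower number a stronger inhibitor of growth), compound 1 gives 2240 nM and compound 2 gives 2530 nM. The change between them is hydrogen in place of methoxy on an aromatic carbon and it produced a 1.1-fold lower number from compound 2 to compound 1 (0.05 log units; within the scatter). Compound 3 `COc1cc(C(=O)/C=C/c2cc(-c3cc(OC)c(OC)c(OC)c3)n[nH]2)cc(OC)c1OC` gives 1490 nM in this assay; the difference between the core of compound 3 and that of compound 2 is not broken down here, and its number lies within the scatter of both earlier values, so no ordering among the three is claimed. Compound 4 `COc1ccc(-c2cc(/C=C/C(=O)c3cc(OC)c(OC)c(OC)c3)[nH]n2)cc1OC` is not yet measured in this assay. It differs from compound 3 by hydrogen in place of methoxy on an aromatic carbon. This is the same kind of change as that between compound 2 and compound 1, with the place now additionally described as meta to a methoxy group. For compound 4 the step expected is a 1.0-fold higher number from compound 3 to compound 4 (0.00 log units; within the scatter), a figure that rests on the earlier 1.1-fold lower number from compound 2 to compound 1 (0.05 log units; within the scatter) for the same kind of change. In this assay compound 4 is therefore estimated at 1500 nM, expected to fall between 700 nM and 3200 nM.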

Compound 4, concentration for 50% growth inhibition: 1780 nM
Estimate against measurement, compound 4: 1.2-fold (0.07 log units) below; the range from low to high includes it.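

Hydrogen in place of methoxy on an aromatic carbon gives a 1.2-fold higher number from compound 3 to compound 4 (0.08 log units; within the scatter) in this assay, and set beside the earlier case, the two steps do not differ: the same change on two cores in this assay, a 1.1-fold lower number (0.05 log units; within the scatter) from compound 2 to compound 1 and a 1.2-fold higher number (0.08 log units; within the scatter) from compound 3 to compound 4, 1.3-fold (0.13 log units) apart, within the scatter of two such steps. On these two cores, then, the change stays within the scatter each time, and the small step read on the core of compound 1 held on the core of compound 3. Within the data shown here, this does not show that methoxy at such a place is without effect across the series, since only two pairs bear on it, and neither a direction nor a size for the step can be drawn from steps this small.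

Open, as far as these compounds go, is what a hydroxyl or a chlorine in place of the methoxy would do on either core. Also open, from the compounds shown here alone, is whether the step stays this small when a second methoxy on the same ring gives way to hydrogen, or on a core other than these two.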